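Compound 3 to compound 4: a change on the carbonyl carbon

A few compounds are considered here, and "the series" means these few. Any claim that something is new, unique, unknown or untested is made for them only; others in the source may bear on it.

Compound 1 `CCn1c(C(=O)NCC#N)ccc1C(CC)(CC)c1ccc(OCCC(O)(CC)CC)c(C)c1` reaches only a limit in a functional assay on MCF7 cells (Homo sapiens) for antiproliferative activity, read by MTT assay, with a stated time of 48 h (a higher number here means a weaker inhibitor, a lower number a stronger inhibitor), > 50000 nM. Going by the values given here, compound 2 `CCC(C)C(NC(=O)c1ccc(C(CC)(CC)c2ccc(OCCC(O)(CC)CC)c(C)c2)n1CC)C(=O)O` gives 11300 nM, and compound 3 `CCn1c(C(=O)N(C)CC(=O)O)ccc1C(CC)(CC)c1ccc(OCCC(O)(CC)CC)c(C)c1` gives 79 nM, the lowest number so far. Compound 4 `CCn1c(C(=O)NC(CO)CCO)ccc1C(CC)(CC)c1ccc(OCCC(O)(CC)CC)c(C)c1` changes compound 3 on a carbonyl carbon: a group of 7 heavy atoms (4 carbon, 1 nitrogen, 2 oxygen; no ring) in place of a group of 6 heavy atoms (3 carbon, 1 nitrogen, 2 oxygen; no ring), on a carbonyl carbon. Two measured steps at this same place bear on it: an at least 630-fold lower number from compound 1 to compound 3 (2.80 log units; beyond the scatter) and a 140-fold lower number from compound 2 to compound 3 (2.16 log units; beyond the scatter), each large. Among the compounds with values here, no measured compound carries the entering group, so the size is uncertain, but a large move to a higher number is expected in this assay. The expected step is a 51-fold higher number from compound 3 to compound 4 (1.70 log units; beyond the scatter). Compound 4 is estimated at 4000 nM, with an expected range of 300 nM to 40000 nM.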

Compound 4, half-maximal inhibitory concentration: 31400 nM
The estimate for compound 4 lay 7.9-fold (0.89 log units) below the measured number, and the stated range covers the measured number.
By their numbers in this assay, from the lowest: compound 3; then compound 2; then compound 4. At a limit, above all of these: compound 1.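

With 3-hydroxy-1-(hydroxymethyl)propyl on the amide-type nitrogen, the low number of the series is lost: there is a 400-fold higher number from compound 3 to compound 4 (2.60 log units; beyond the scatter), while the gap to another compound that keeps the amide hydrogen is much smaller, with a 2.8-fold higher number from compound 2 to compound 4 (0.44 log units; beyond the scatter). So far, only compound 3 lacks the amide hydrogen; compounds 1, 2 and 4 all keep it, and compounds 2 and 4 give far higher numbers. Compound 1 gives only a limit, > 50000 nM. Against that limit there is an at least 1.5-fold lower number from compound 1 to compound 4 (0.20 log units; that floor lies within the scatter).

From the compounds shown here alone, it remains open whether the methyl on nitrogen or the carboxymethyl carries the low number of compound 3. A plain dimethylamino group and a (carboxymethyl)amino group would separate the two.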